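A few compounds are considered here, and "the series" means these few. Any claim that something is new, unique, unknown or untested is made for them only; others in the source may bear on it.

Compound 1 `COc1ccccc1-c1oc2ccc(NC(C)=O)cc2c(=O)c1O`, compound 2 `CC(=O)Nc1ccc2oc(-c3ccccc3F)c(O)c(=O)c2c1` and compound 3 `COc1cccc(-c2oc3ccc(N)cc3c(=O)c2O)c1` were tested in an ADME assay on THP-1 cells (Homo sapiens) for cytotoxicity, read by flow cytometry and propidium iodide staining, with a stated time of 72 h; a higher number here means a weaker inhibitor, a lower number a stronger inhibitor. For compound 1 the result is only a limit, > 125000 nM, (the limit of > 125000 nM in this assay, at which 1 of the 3 values shown sits). In this assay compound 2 gives 47000 nM, and compound 3 gives 2000 nM, the lowest of the two numbers.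

For the measured compounds named here, the one change between compound 1 and compound 2 is fluoro in place of methoxy on an aromatic carbon, and it brought an at least 2.6-fold lower number from compound 1 to compound 2 (0.42 log units; beyond the scatter). Compound 4 `Nc1ccc2oc(-c3cccc(F)c3)c(O)c(=O)c2c1` has not yet been measured. It differs from compound 3 by fluoro in place of methoxy on an aromatic carbon, the same kind of change, though here the group sits meta to a large group rather than ortho to it. How the core of compound 3 differs from that of compound 1 is not broken down here.

On the strength of that earlier step, compound 4 is expected to show a 2.0-fold lower number from compound 3 to compound 4 (0.30 log units; within the scatter), so the estimate for compound 4 is 1000 nM, between 300 nM and 4000 nM.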

Compound 4, half-maximal inhibitory concentration: 30000 nM
The estimate for compound 4 lay 30-fold (1.48 log units) below the measured number; measured number above the stated range.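

In this assay, fluoro in place of methoxy gave a 15-fold higher number from compound 3 to compound 4 (1.18 log units; beyond the scatter), so the effect of this change did not carry over from one core to the other, and its direction was reversed: the same change on two cores in this assay, an at least 2.6-fold lower number (0.42 log units; beyond the scatter) from compound 1 to compound 2 and a 15-fold higher number (1.18 log units; beyond the scatter) from compound 3 to compound 4, at least 39-fold (1.60 log units) apart, beyond the scatter of two such steps

The earlier step starts from compound 1, whose > 125000 nM is a limit of the assay and not a number. These two pairs do not show why the steps differ, since the cores differ and in compound 4 the fluoro sits meta to a large group, and the two influences cannot be separated here.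

Left open is how a chloro or a nitrile in that place would compare on the core of compound 3. Also open, as far as these compounds go, is whether the step seen here would hold on any further core.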